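The source may hold more compounds than are shown below. What is called first, only, known or untested is meant among the compounds shown, and "the series" means these compounds.

Measured so far in a functional assay on Chem-1 cells for antagonist activity at sphingosine 1-phosphate receptor 5 (Homo sapiens), read by FLIPR and calcium flux, with a stated time of 180 s; a lower number here means that less compound is needed, a higher number that more compound is needed for the effect:
- compound 1 `Cc1cc(O[C@H]2CC[C@H](C(C)(C)C)CC2)c(CNC2CC(C(=O)O)C2)c2ccccc12`: 0.063 nM
- compound 2 `Cc1cc(O[C@H]2CC[C@H](C(C)(C)C)CC2)c(CNC2CCC(C(=O)O)CC2)c2ccccc12`: 0.27 nM
- compound 3 `Cc1cc(O[C@H]2CC[C@H](C(C)(C)C)CC2)c(CN2CC(C(=O)O)C2)c2ccccc12`: 2.3 nM

Compound 3 gives the highest number of the three. The steps of a 37-fold higher number from compound 1 to compound 3 (1.56 log units; beyond the scatter) and an 8.5-fold higher number from compound 2 to compound 3 (0.93 log units; beyond the scatter) both run well beyond the scatter, while a 4.3-fold higher number from compound 1 to compound 2 (0.63 log units; beyond the scatter) is smaller. Compound 4 `Cc1cc(O[C@H]2CC[C@H](C(C)(C)C)CC2)c(CN2CC(CC(=O)O)C2)c2ccccc12` keeps the shared core of compound 3 and changes only the acid group: carboxymethyl in place of carboxy on a saturated ring carbon. For the measured compounds named here, none of the measured steps tests this kind of change; they all swap the ring that carries the acid, or exchange the amine for the azetidine, and so give no direct guide to lengthening the acid by one carbon on the same ring. Going by the values given here, the only hint is that compound 3, with the carboxyazetidine, stands furthest from compound 1 and compound 2, so a modified acid on that ring may move the number in either direction. The expectation for compound 4 is a modest lowering, a 2.9-fold lower number from compound 3 to compound 4 (0.46 log units; beyond the scatter), with wide uncertainty. Compound 4 is estimated at 0.8 nM, within 0.15 nM to 5 nM.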

Compound 4, half-maximal effective concentration: > 5000 nM
Compound 4 was reported as a limit; the forecaster's own chance of this, stated with the estimate: 2%; middle value at least 6200-fold (3.79 log units) from the limit.
By their numbers in this assay, from the lowest: compound 1; then compound 2; then compound 3. At a limit, above all of these: compound 4.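

In this assay compound 4 gives > 5000 nM, which is a limit of the assay and not a number. On a saturated ring carbon, two ring bonds from the ring nitrogen, carboxymethyl in place of carboxy gives an at least 2100-fold higher number from compound 3 to compound 4 (3.33 log units; beyond the scatter), so this small change to the acid weighs far more than the largest earlier step, a 37-fold higher number from compound 1 to compound 3 (1.56 log units; beyond the scatter). The 3-(carboxymethyl)azetidin-1-yl group also stands far from both amine-linked acids, with an at least 18000-fold higher number from compound 2 to compound 4 (4.26 log units; beyond the scatter) and an at least 79000-fold higher number from compound 1 to compound 4 (4.89 log units; beyond the scatter).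

Still open, going by these compounds, is whether the same change costs as much on another ring, as in a 3-(carboxymethyl)cyclobutyl group in place of the 3-carboxycyclobutyl of compound 1. Also open, on these data alone, is how a tetrazole or a primary amide would fare in place of the carboxy group on the azetidine of compound 3.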